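Notes on the series: methoxy in place of hydrogen

The source may report more compounds than this note shows. Statements on the series, on what has been measured and on what is new or still open speak of the compounds shown alone.

Values in a functional assay on HeLa cells (Homo sapiens) for antiproliferative activity, read by sulforhodamine B assay, with a stated time of 72 h (on this read-out higher numbers stand for weaker inhibition and lower numbers for stronger inhibition), so far:
Compound 1 `COc1cccc(NC(=S)N/N=C/c2ccc3ccccc3n2)c1` gives 74500 nM.
Compound 2 `Cc1ccccc1NC(=S)N/N=C/c1ccc2ccccc2n1` gives > 100000 nM, which is a limit of the assay and not a number.
Compound 3 `S=C(N/N=C/c1ccc2ccccc2n1)Nc1ccccc1` gives 27400 nM.

Compound 3 has the lowest number of the two plain numbers; the nearest is compound 1, and the step of a 2.7-fold lower number from compound 1 to compound 3 (0.43 log units; beyond the scatter) is beyond the scatter. From compound 2 the step of an at least 3.6-fold lower number from compound 2 to compound 3 (0.56 log units; beyond the scatter) is at least modest, read against (the limit of > 100000 nM in this assay, at which 1 of the 3 values shown sits).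

Compound 4 `COc1ccccc1NC(=S)N/N=C/c1ccc2ccccc2n1` is not yet measured. It differs from compound 3 by methoxy in place of hydrogen on an aromatic carbon.

Within the data shown here, two measured steps bear on this. Removing methoxy, a 2.7-fold lower number from compound 1 to compound 3 (0.43 log units; beyond the scatter), lowered the number; removing methyl, an at least 3.6-fold lower number from compound 2 to compound 3 (0.56 log units; beyond the scatter), lowered it further still. Both say that a substituent on the six-membered aromatic ring of carbon only makes the number higher than in the bare phenyl of compound 3. The new methoxy sits where the methyl of compound 2 sat, and a methoxy elsewhere on the ring, in compound 1, already gave a higher number. A step upward from compound 3 to compound 4 in this assay is therefore expected, likely modest to large, with a real chance of only a limit being reported.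

Compound 4 is expected at 80000 nM, between 30000 nM and 200000 nM, which means an expected step of a 2.9-fold higher number from compound 3 to compound 4 (0.47 log units; beyond the scatter).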

Compound 4, half-maximal inhibitory concentration: > 100000 nM
Compound 4 was reported as a limit; the forecaster's own chance of this, stated with the estimate: 40%; at least 1.2-fold (0.09 log units) between middle value and limit.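

In this assay, among these compounds, the change from phenyl to 2-methoxyphenyl gives an at least 3.6-fold higher number from compound 3 to compound 4 (0.56 log units; beyond the scatter), so a methoxy ortho to a large group raises the number beyond the scatter, whereas the earlier compounds showed a methoxy step only for the 3-methoxyphenyl of compound 1. Between the two placings of methoxy the comparison reads an at least 1.3-fold higher number from compound 1 to compound 4 (0.12 log units; that floor lies within the scatter), and with that floor within the scatter no order between them can be claimed. The step between the methyl and the methoxy at this place cannot be read, as both compounds stand at a limit of the assay and not at a number: the limit of > 100000 nM in this assay, at which 2 of the 4 values shown sit.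

Still open, on these data alone, is whether fluoro, hydroxy or an amine at this place would stay near compound 3, which gives 27400 nM. Also open, as far as these compounds go, are how a carboxylic acid on the same ring would read and what lies beyond the limits reached by compound 2 and compound 4.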